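This account rests on a few compounds, and the source may have more. Where it says the series, first, only, none or still open, it means among the compounds named here.

Measured so far in a physicochemical assay for lipophilicity (on this read-out lower numbers stand for lower lipophilicity and higher numbers for higher lipophilicity), for two compounds:
- compound 1 `CCOc1ccccc1C1=NC(c2ccccc2)CO1` gives 4.22
- compound 2 `O=[N+]([O-])c1ccccc1C1=NC(c2ccccc2)CO1` gives 2.83

Among the measured compounds shown here, compound 2 at 2.83 holds the lower of the two numbers, and compound 1 at 4.22 is its only neighbour.

Compound 3 `c1ccc(Oc2ccccc2C2=NC(c3ccccc3)CO2)cc1` is not yet measured. The change from compound 2 is phenoxy in place of nitro on an aromatic carbon with phenoxy in place of nitro on an aromatic carbon, ortho to a large group.

For the measured compounds named here, one measured step bears on this change. The step of a number 1.39 log units lower from compound 1 to compound 2 (beyond the scatter) is large and beyond the scatter, and it puts nitro in place of ethoxy on an aromatic carbon. Going by the values given here, compound 3 removes that nitro but carries phenoxy rather than ethoxy, and no measured step involves phenoxy, so the read-across is only partial. Phenoxy brings an aromatic ring that ethoxy lacks. A large rise in this assay is therefore expected, somewhat greater than a number 1.39 log units lower from compound 1 to compound 2 (beyond the scatter) read in reverse. The expected size is a number 2.17 log units higher from compound 2 to compound 3 (beyond the scatter) on this reasoning. Compound 3 is estimated at 5 with a range of 4.4 to 5.6 expected.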

Compound 3, partition coefficient: 5.61
For compound 3 the middle estimate is 0.61 log units below the measured one; measured number outside the range, above it.
By their numbers in this assay, from the lowest: compound 2; then compound 1; then compound 3.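

In this assay the place ortho to a large group now shows three groups whose numbers all stand apart beyond the scatter, with nitro lowest, ethoxy in the middle and phenoxy highest. Phenoxy in place of nitro gives a number 2.78 log units higher from compound 2 to compound 3 (beyond the scatter) and is the widest step in the set. With the oxygen on the aromatic ring kept, phenyl in place of ethyl gives a number 1.39 log units higher from compound 1 to compound 3 (beyond the scatter) and so matches in size, in the opposite direction, the exchange of ethoxy for nitro that gave a number 1.39 log units lower from compound 1 to compound 2 (beyond the scatter) on the same aromatic carbon: changing only what sits on that oxygen moves the number as far as replacing the whole ethoxy group did.

Nothing measured on these compounds accounts for the size of either new step.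

As far as these compounds go, whether this order holds for other groups at this place, such as an amine, a carboxylic acid or a longer alkoxy chain, remains open. Also open, from the compounds shown here alone, is whether a substituted phenyl on the oxygen, or the same exchanges at another carbon of the ring, would give steps of this size.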